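Fluorobenzyl for methylbenzyl on a rhodanine-benzimidazole series

The compounds below may be only part of what the source reports. "The series", "measured", "known", "first", "only" and "open" are said of these compounds alone.

Measured compounds:
compound 1, `Cc1ccc(Cn2c(/C=C3\SC(=S)N(CC(=O)O)C3=O)nc3cc(Cl)ccc32)cc1`, 26700 nM
compound 2, `Cc1ccc(Cn2c(/C=C3\SC(=S)NC3=O)nc3ccccc32)cc1`, 9780 nM
compound 3, `O=C(O)CN1C(=O)/C(=C/c2nc3cc(Cl)ccc3n2Cc2ccccc2F)SC1=S`, 3480 nM

The three measured compounds were tested in a functional assay on PC-3 cells (Homo sapiens) for cytotoxicity, read by MTT assay, with a stated time of 48 h; a higher number here means a weaker inhibitor, a lower number a stronger inhibitor. Compound 1 gives 26700 nM, compound 2 gives 9780 nM, and compound 3 gives 3480 nM. Compound 2 stands between the other two, with its steps to both lying beyond the scatter.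

Compounds 1 and 3 differ in one place, described by 2-fluorophenyl in place of 4-methylphenyl on a saturated chain carbon bound to an aromatic nitrogen. The step was a 7.7-fold lower number from compound 1 to compound 3 (0.88 log units; beyond the scatter), a modest change in favour of compound 3.

Compound 4, `O=C1NC(=S)S/C1=C\c1nc2ccccc2n1Cc1ccccc1F`, has not been measured. For the measured compounds named here, it differs from compound 2 by 2-fluorophenyl in place of 4-methylphenyl on a saturated chain carbon bound to an aromatic nitrogen, which is the same kind of change as the one between compounds 1 and 3, at the same place. The difference between the core of compound 1 and the core of compound 2 is not broken down here; the two differ in more than one place.

Going by the values given here, because the single measured instance of this change gave a 7.7-fold lower number from compound 1 to compound 3 (0.88 log units; beyond the scatter), compound 4 is expected to show a lower number than compound 2 in this assay. Among the compounds with values here, since only one example exists and the cores differ, the expected step is tempered: it is estimated as a 5.4-fold lower number from compound 2 to compound 4 (0.74 log units; beyond the scatter). The estimate for compound 4 is 1800 nM, with a range from 500 nM to 6500 nM.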

Compound 4, half-maximal inhibitory concentration: > 50000 nM
Compound 4: only a limit was reported; the forecaster's own chance of this, stated with the estimate: 5%; middle value at least 27-fold (1.44 log units) away from the limit.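

In this assay compound 4 gives > 50000 nM, which is a limit of the assay and not a number. For the compounds shown here, on the core of compound 2, the change from 4-methylbenzyl to 2-fluorobenzyl gave an at least 5.1-fold higher number from compound 2 to compound 4 (0.70 log units; beyond the scatter), whereas on the core of compound 1 it lowered the number, so in these two pairs the change did not carry from one core to the other: the same change on two cores in this assay, a 7.7-fold lower number (0.88 log units; beyond the scatter) from compound 1 to compound 3 and an at least 5.1-fold higher number (0.70 log units; beyond the scatter) from compound 2 to compound 4, at least 39-fold (1.59 log units) apart, beyond the scatter of two such steps With only one pair on each core, and with cores that differ in more than one place, this does not show which of those differences goes with the reversal, and the step on the core of compound 2 is known only as a bound.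

The compounds shown leave open how the change behaves on a core carrying the chlorine without the carboxylic acid chain, or the carboxylic acid chain without the chlorine, which would help separate the two differences. Also open, as far as these compounds go, is how an unsubstituted benzyl group would compare with both substituted ones on each core, and what a longer acid chain or an amine in place of the carboxylic acid would do.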